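A few compounds are considered here, and "the series" means these few. Any claim that something is new, unique, unknown or untested is made for them only; others in the source may bear on it.

Measured in a functional assay on MCF7 cells (Homo sapiens) for antiproliferative activity, read by MTT assay, with a stated time of 72 h; a higher number here means a weaker inhibitor, a lower number a stronger inhibitor:
Compound 1 `COc1ccc(-c2ccc3ncn(-c4cc(OC)c(OC)c(OC)c4)c3c2)cc1F`: 520 nM
Compound 2 `COc1cc(-n2cnc3ccc(-c4ccccc4)cc32)cc(OC)c1OC`: 2290 nM
Compound 3 `COc1cc(-n2cnc3ccc(-c4cccc([N+](=O)[O-])c4)cc32)cc(OC)c1OC`: 4560 nM

In this assay, compound 3 gives 4560 nM. Its nearest neighbour is shown by a 2.0-fold higher number from compound 2 to compound 3 (0.30 log units; within the scatter), and the furthest by an 8.8-fold higher number from compound 1 to compound 3 (0.94 log units; beyond the scatter). Compound 4 `COc1cc(-n2cnc3ccc(-c4ccc(Cl)cc4)cc32)cc(OC)c1OC` differs from it by 4-chlorophenyl in place of 3-nitrophenyl on an aromatic carbon. Among the compounds with values here, no measured compound carries 4-chlorophenyl, so the evidence is indirect. The most relevant steps are the changes at this same place, chiefly a 4.4-fold higher number from compound 1 to compound 2 (0.64 log units; beyond the scatter), with phenyl in place of 3-fluoro-4-methoxyphenyl. The data do not show whether 4-chlorophenyl will track the 3-fluoro-4-methoxyphenyl of compound 1, at 520 nM, or the phenyl of compound 2, at 2290 nM. A position between these two values is therefore expected, which means a modest move to a lower number, with the expected step being a 2.9-fold lower number from compound 3 to compound 4 (0.45 log units; beyond the scatter). For compound 4 the estimated value is 1600 nM, with an expected range from 600 nM to 4000 nM.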

Compound 4, half-maximal inhibitory concentration: 1320 nM
Compound 4: the middle estimate sits 1.2-fold (0.08 log units) above what was measured; low and high end bracket the measured number.
By their numbers in this assay, from the lowest: compound 1; then compounds 4, 2 and 3 (each within the scatter of the next, the first and the last beyond it).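

In this assay, chloro in place of hydrogen on the phenyl ring leaves the number within the scatter, with a 1.7-fold lower number from compound 2 to compound 4 (0.24 log units; within the scatter). Even so, 4-chlorophenyl and 3-nitrophenyl, each within the scatter of plain phenyl, stand apart from one another, with a 3.5-fold lower number from compound 3 to compound 4 (0.54 log units; beyond the scatter), so the choice of substituted phenyl at this place can register in the assay. Adding chloro does not close the gap to the 3-fluoro-4-methoxyphenyl of compound 1, as shown by a 2.5-fold higher number from compound 1 to compound 4 (0.40 log units; beyond the scatter).

From the compounds shown here alone, whether 3-fluorophenyl or 4-methoxyphenyl alone would match compound 1 remains open. Also open, going by these compounds, is how an aminophenyl or a phenyl carrying a carboxylic acid would behave at this place. Nothing available here explains these differences in terms of mechanism.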